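The source may hold more compounds than are shown below. What is called first, only, known or untested is meant among the compounds shown, and "the series" means these compounds.

Measured compounds:
Compound 1, `Cc1ccc2c(c1)[n+]([O-])c(NCCN(C)C)n[n+]2[O-]` — in a physicochemical assay for solubility, in the presence of a further agent that is not named here (a lower number here means a less soluble compound, a higher number a more soluble compound), compound 1 gives > 51000000 nM, which is a limit of the assay and not a number.
Compound 2, `CCOc1ccc2c(c1)[n+]([O-])c(NCCN(C)C)n[n+]2[O-]` — in this assay compound 2 gives > 50000000 nM, again a limit rather than a number.

For the measured compounds named here, compound 2 therefore stands only at a limit, and the one other value shown is a limit as well. The change from compound 1, ethoxy in place of methyl on an aromatic carbon, reads as a step that the two limits leave unreadable from compound 1 to compound 2, unreadable because the limit of > 50000000 nM in this assay, at which 1 of the 2 values shown sits, and the limit of > 51000000 nM in this assay, at which 1 of the 2 values shown sits, are both limits. Compound 3, `COCCOc1ccc2c(c1)[n+]([O-])c(NCCN(C)C)n[n+]2[O-]`, differs from compound 2 by methoxy in place of hydrogen on a saturated chain carbon, two bonds along the chain from an oxygen on an aromatic ring. Going by the values given here, no measured step gives a number, so the two limits are all that bear on this change, and nothing indicates a movement beyond the scatter. The expected step in this assay is a step that the limit leaves unreadable from compound 2 to compound 3, most likely again ending at a limit. Compound 3 is estimated at 60000000 nM, within 30000000 nM to 120000000 nM.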

Compound 3, solubility: 43000000 nM
Beside the measured number, compound 3's estimate is 1.4-fold (0.14 log units) above it; measured number inside the range.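

In this assay, compound 3 is the only compound shown with a number rather than a limit, so the change to 2-methoxyethoxy can now be read as an at least 1.1-fold lower number from compound 2 to compound 3 (0.06 log units; that floor lies within the scatter), and the change from methyl on the aromatic carbon as an at least 1.1-fold lower number from compound 1 to compound 3 (0.07 log units; that floor lies within the scatter). From the compounds shown here alone, both steps are floors only, and the true size of the first stays unknown because compound 2 stands at a limit: the limit of > 50000000 nM in this assay, at which 1 of the 3 values shown sits. The true size of the second stays unknown for the same kind of reason, because compound 1 also stands at a limit: the limit of > 51000000 nM in this assay, at which 1 of the 3 values shown sits.

The compounds shown leave open whether this change moves the number beyond the scatter at all. They also leave open how an amine, a carboxylic acid or a longer chain in place of the methoxy would read in this assay.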